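Working notes on compound 2 and compound 3

The source may hold more compounds than are shown below. What is called first, only, known or untested is meant among the compounds shown, and "the series" means these compounds.

- compound 1 `Cc1ccc(S(=O)(=O)/C(=C/c2ccc(C)s2)C(=O)c2ccc(Br)cc2)cc1` gives 25000 nM in a functional assay on DU-145 cells (Homo sapiens) for inhibition, read by trypan blue exclusion, with a stated time of 96 h; on this read-out higher numbers stand for weaker inhibition of growth and lower numbers for stronger inhibition of growth
- compound 2 `Cc1ccc(/C=C(/SCc2ccc(Cl)cc2Cl)C(=O)c2ccc(Cl)cc2)s1` gives 50000 nM in this assay

For the measured compounds named here, these are the only two numbers available in this assay for the series. Compound 2 stands at 50000 nM and lies within the scatter of compound 1, so no order can be drawn between them.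

The next compound to be read is compound 3 `Cc1ccsc1/C=C(/SCc1ccc(Cl)cc1Cl)C(=O)c1ccc(Cl)cc1`, which has the same atoms as compound 2, joined differently. The change is 3-methylthiophen-2-yl in place of 5-methylthiophen-2-yl on a double-bonded chain carbon bound to a double-bonded chain carbon, with 3-methylthiophen-2-yl in place of 5-methylthiophen-2-yl on a double-bonded chain carbon bound to a double-bonded chain carbon.

Going by the values given here, no measured pair shows what this kind of change does. Among the compounds with values here, with no such step to draw on, the expectation rests on compound 2 at 50000 nM as the closest reference, and no step beyond the scatter is expected in this assay. The expected size is a 1.3-fold lower number from compound 2 to compound 3 (0.10 log units; within the scatter) and it remains an estimate only. The estimate for compound 3 is 40000 nM, with the expected range running from 15000 nM to 90000 nM in this series.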

Compound 3, concentration for 50% growth inhibition: 10000 nM
Compound 3: the middle estimate sits 4.0-fold (0.60 log units) above what was measured; the whole stated range lies above it.
By their numbers in this assay, from the lowest: compound 3; then compounds 1 and 2 (each within the scatter of the next).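

In this assay, for the compounds shown here, 3-methylthiophen-2-yl in place of 5-methylthiophen-2-yl on a double-bonded chain carbon bound to a double-bonded chain carbon gives a modest change (a 5.0-fold lower number from compound 2 to compound 3 (0.70 log units; beyond the scatter)), and this is the first step that lies beyond the scatter. Compounds 2 and 3 have the same atoms and differ in this one place only, so the read-out at this position responds to how the methylthiophenyl group is joined, not only to which atoms it holds. No available measurement accounts for the size or direction of this step.

The compounds shown leave open whether the same change would give a similar step on the core of compound 1, and a single pair cannot establish a trend at this position. They also leave open how this position would respond if the methyl group of 3-methylthiophen-2-yl were replaced by an ethyl group, a methoxy group or a carboxylic acid.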